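The source may report more compounds than this note shows. Statements on the series, on what has been measured and on what is new or still open speak of the compounds shown alone.

Working notes on a small set of quinoline sulfones tested for turnover in an ADME assay on microsomes from liver (Homo sapiens) for metabolic stability, tested at 2.5 uM; on this read-out higher numbers stand for fast clearance and lower numbers for slow clearance.

Compound 1 `O=S(=O)(c1cc(F)cc(F)c1)c1cnc2cc(F)ccc2c1-c1ccc(Cl)cc1` is the anchor of the pair with the first core; in this assay compound 1 gives 0.03 mL/min. Compound 2 `O=S(=O)(c1cc(F)cc(F)c1)c1cnc2cc(F)ccc2c1-c1cccc(F)c1` carries the change 3-fluorophenyl in place of 4-chlorophenyl on an aromatic carbon on that core, and in this assay compound 2 gives 0.06 mL/min. The measured step is a 2.0-fold higher number from compound 1 to compound 2 (0.30 log units; within the scatter), so the two numbers are not told apart here.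

Compound 3 `O=S(=O)(c1ccc(F)c(Cl)c1)c1cnc2c(F)cccc2c1-c1ccc(Cl)cc1` belongs to a second core; the difference between the two cores is not broken down here. In this assay compound 3 gives 0.01 mL/min, the lowest of the three numbers, with compound 1 nearest and compound 2 furthest from it, both gaps beyond the scatter.

Compound 4 `O=S(=O)(c1ccc(F)c(Cl)c1)c1cnc2c(F)cccc2c1-c1cccc(F)c1` is the unmeasured member. It stands to compound 3 as compound 2 stands to compound 1: the change is 3-fluorophenyl in place of 4-chlorophenyl on an aromatic carbon, and the surroundings of the place are the same word for word as in the first pair, so this is the same change and not merely the same kind. Because the measured step of a 2.0-fold higher number from compound 1 to compound 2 (0.30 log units; within the scatter) is this same change on the other core, the expected step is a 2.0-fold higher number from compound 3 to compound 4 (0.30 log units; within the scatter). Going by the values given here, only one earlier instance of the change exists, so the expectation rests on a single pair. Compound 4 is therefore expected to give 0.02 mL/min in this assay, with a plausible range from 0.01 mL/min to 0.05 mL/min, pending the actual readout.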

Compound 4, intrinsic clearance in a liver preparation (reported as CLH), per the amount of preparation that the assay uses: 1.23 mL/min
Estimate against measurement, compound 4: 62-fold (1.79 log units) below; measured number above the stated range.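

On the core of compound 3, 3-fluorophenyl in place of 4-chlorophenyl gives a 120-fold higher number from compound 3 to compound 4 (2.09 log units; beyond the scatter) in this assay, a large step, and it does not match the same change on the core of compound 1: the same change on two cores in this assay, a 2.0-fold higher number (0.30 log units; within the scatter) from compound 1 to compound 2 and a 120-fold higher number (2.09 log units; beyond the scatter) from compound 3 to compound 4, 62-fold (1.79 log units) apart, beyond the scatter of two such steps. The step measured on one core therefore cannot be carried to the other in this series, since the same swap at the same place can stay within the scatter on one core and rise far beyond it on the second. Going by these compounds alone, what this does not show is why the two cores part, or which of their differences matters, and with only two pairs it gives no general rule for how this change behaves across the series.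

The compounds shown leave open whether the large step follows the aryl group on the sulfone or the placement of the fluorine on the fused ring system, as no pair here changes one of these alone. Also open, as far as these compounds go, is how a different group in the place of 4-chlorophenyl, such as a nitrile-bearing phenyl, an amine or a carboxylic acid, would behave on either core.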